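The compounds below may be only part of what the source reports. "The series", "measured", "known", "first", "only" and "open" are said of these compounds alone.

Working notes on the series. Among the compounds with values here, in a functional assay on A-431 cells (Homo sapiens) for antiproliferative activity, read by MTT assay, with a stated time of 72 h (on this read-out higher numbers stand for weaker inhibition and lower numbers for stronger inhibition), compound 1 `COc1cc2ncnc(Nc3cccc(F)c3)c2cc1OCCCCC(=O)Nc1ccc(S(N)(=O)=O)cc1` gives 29900 nM and compound 2 `COc1cc2ncnc(Nc3cccc(C)c3)c2cc1OCCCCC(=O)Nc1ccc(S(N)(=O)=O)cc1` gives 7460 nM; the one measured step, a 4.0-fold lower number from compound 1 to compound 2 (0.60 log units; beyond the scatter), leaves compound 2 with the lowest of the two numbers. Compound 3 `COc1cc2ncnc(Nc3ccc(C)cc3)c2cc1OCCCCC(=O)Nc1ccc(S(N)(=O)=O)cc1` differs from compound 2 by 4-methylphenyl in place of 3-methylphenyl on a nitrogen on an aromatic ring. No measured step changes the position of a group on this ring, so nothing shown bears directly on it; the only step known swaps the group itself. In this assay compound 3 is therefore expected to show a step of a 1.2-fold higher number from compound 2 to compound 3 (0.08 log units; within the scatter), not clearly beyond the scatter. The estimate for compound 3 is 9000 nM, within 3000 nM to 30000 nM.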

Compound 3, half-maximal inhibitory concentration: 35500 nM
Compound 3: the middle estimate sits 3.9-fold (0.60 log units) below what was measured; measured number above the stated range.
By their numbers in this assay, from the lowest: compound 2; then compounds 1 and 3 (each within the scatter of the next).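

The same methyl group, moved from 3-methylphenyl to 4-methylphenyl on the nitrogen, changes the result in this assay, with a 4.8-fold higher number from compound 2 to compound 3 (0.68 log units; beyond the scatter); the place of the group on this ring therefore counts, not only its identity. A methyl group alone does not lower the number, as 4-methylphenyl and 3-fluorophenyl do not separate, with a 1.2-fold higher number from compound 1 to compound 3 (0.07 log units; within the scatter). Nothing available accounts for this difference between the two placements. The compounds shown leave open whether a 4-fluorophenyl or 4-chlorophenyl group would read like 4-methylphenyl, and whether 3-chlorophenyl would match 3-methylphenyl.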